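Chalcone series: phenyl replacing trimethoxyphenyl on the carbonyl

The source may hold more compounds than are shown below. What is called first, only, known or untested is meant among the compounds shown, and "the series" means these compounds.

Compound 1 `COc1cc(C(=O)/C=C/c2cc(-c3cc(OC)c(OC)c(OC)c3)n3nc(-c4ccccc4)cc3n2)cc(OC)c1OC` gives, in an ADME assay on HEK293 cells (Homo sapiens) for antiproliferative activity, read by MTT assay, with a stated time of 24 h (a lower number here means a stronger inhibitor, a higher number a weaker inhibitor), a reading of >= 100000 nM, which is a limit of the assay and not a number. Among the values shown, compound 1 stands at the weak end, as the limit of >= 100000 nM in this assay, at which 1 of the 3 values shown sits, records. Compound 2 `COc1ccc(-c2cc(/C=C/C(=O)c3cc(OC)c(OC)c(OC)c3)nc3cc(-c4ccccc4)nn23)cc1OC` gives 35000 nM in this assay, and the change is an at least 2.8-fold lower number from compound 1 to compound 2 (0.45 log units; beyond the scatter). Compound 3 `COc1ccc(-c2cc(/C=C/C(=O)c3ccc(C)c(C)c3)nc3cc(-c4ccccc4)nn23)cc1OC` gives 46200 nM in this assay; the exchange on the carbonyl carbon produced a 1.3-fold higher number from compound 2 to compound 3 (0.12 log units; within the scatter). Compound 4 `COc1cc(-c2cc(/C=C/C(=O)c3ccccc3)nc3cc(-c4ccccc4)nn23)cc(OC)c1OC` has not been measured in this assay. It differs from compound 1 by phenyl in place of 3,4,5-trimethoxyphenyl on a carbonyl carbon. The step from compound 2 to compound 3 bears on this change, as it also replaced the 3,4,5-trimethoxyphenyl on the carbonyl carbon, and it stayed within the scatter. The step from compound 1 to compound 2 does not concern this position. No movement beyond the scatter is therefore expected here, and compound 4 is expected to remain near the limit, the estimated step being a number no higher from compound 1 to compound 4 (the limit leaves the size open). Compound 4 is estimated at 100000 nM, with a range from 40000 nM to 250000 nM, and a limit-only reading is considered likely.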

Compound 4, half-maximal inhibitory concentration: >= 100000 nM
Compound 4 was reported as a limit; the forecaster's own chance of this, stated with the estimate: 60%; the middle value lies on the limit itself.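

The step between compound 1 and compound 4 cannot be read, as both readings are limits of the assay and not numbers: the limit of >= 100000 nM in this assay, at which 2 of the 4 values shown sit. Left open is how far phenyl in place of 3,4,5-trimethoxyphenyl on a carbonyl carbon moves the number in this assay for this pair.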